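This account rests on a few compounds, and the source may have more. Where it says the series, first, only, none or still open, it means among the compounds named here.

Measured compounds:
- compound 1, `CC(=O)Oc1ccccc1C(=O)O[C@H]1CO[C@H]2[C@@H]1OC[C@H]2OC(=O)c1ccc(O)cc1`: 0.0198 h
- compound 2, `CCC(=O)O[C@@H]1CO[C@H]2[C@@H]1OC[C@@H]2OC(=O)c1ccccc1OC(C)=O`: 0.011 h
- compound 3, `CC(=O)Oc1ccccc1C(=O)O[C@H]1CO[C@H]2[C@@H]1OC[C@H]2OC(=O)C1CC1`: 0.015 h

These three compounds share one core and differ only in the group attached to one carbonyl carbon. In an ADME assay on a cell-free system (plasma, Homo sapiens) for metabolic stability, with Plasma (Rattus norvegicus) as the target, read by HPLC, at pH 7.4 (a lower number here means that the compound disappears faster, a higher number that the compound lasts longer), compound 1 gives 0.0198 h, which is the high end of the three numbers shown. Yet the steps of a 1.8-fold lower number from compound 1 to compound 2 (0.26 log units; within the scatter) and a 1.3-fold lower number from compound 1 to compound 3 (0.12 log units; within the scatter) both fall within the scatter, and so does a 1.4-fold higher number from compound 2 to compound 3 (0.13 log units; within the scatter); on these numbers the three compounds cannot be told apart.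

Compound 4, `COc1ccccc1C(=O)O[C@@H]1CO[C@H]2[C@@H]1OC[C@@H]2OC(=O)c1ccccc1OC(C)=O`, is the next compound to be measured in this assay. It differs from compound 1 at the same carbonyl carbon: 2-methoxyphenyl in place of 4-hydroxyphenyl on a carbonyl carbon

The three measured steps all bear on this change, since each swapped the group on that carbonyl carbon, and none of them moved the half-life beyond the scatter. Compound 4 introduces an aromatic group where the others brought in ethyl or cyclopropyl, but nothing in the measured steps suggests that a change at this position shifts the half-life much. Compound 4 is therefore expected to stay close to compound 1, with a 1.1-fold lower number from compound 1 to compound 4 (0.04 log units; within the scatter), a step not beyond the scatter. The estimate for compound 4 is 0.018 h, with a range from 0.009 h to 0.036 h.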

Compound 4, half-life: 0.0165 h
The estimate for compound 4 lay 1.1-fold (0.04 log units) above the measured number; measured number inside the range.
By their numbers in this assay, from the lowest: compounds 2, 3, 4 and 1 (each within the scatter of the next).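

Compound 4 brings a second aromatic group to this carbonyl carbon, and exchanging 4-hydroxyphenyl, which has a hydrogen-bond donor, for 2-methoxyphenyl, which has none, gives in this assay only a 1.2-fold lower number from compound 1 to compound 4 (0.08 log units; within the scatter) as its step. The comparisons with the two non-aromatic groups read the same way, with a 1.1-fold higher number from compound 3 to compound 4 (0.04 log units; within the scatter) against cyclopropyl and a 1.5-fold higher number from compound 2 to compound 4 (0.18 log units; within the scatter) against ethyl as the steps. Ethyl, cyclopropyl, 4-hydroxyphenyl and 2-methoxyphenyl therefore cannot be told apart at this position, now including a pair of aromatic groups with different substituents, and no measurement is available to say why the half-life stays so similar across them.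

As far as these compounds go, what stays open is whether a quite different group on this carbonyl carbon, such as a longer chain, an amine or a carboxylic acid on the aromatic ring, would give a step beyond the scatter. These four compounds also leave open whether a change elsewhere on the shared core would move the half-life, since only this one place varies among them.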